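Inverting one stereocentre of compound 2

The compounds below may be only part of what the source reports. "The series", "measured", "known", "first", "only" and "open" are said of these compounds alone.

In a functional assay on HCT-8 cells (Homo sapiens) for cytotoxicity, read by MTT assay, with a stated time of 24 h (a higher number here means a weaker inhibitor, a lower number a stronger inhibitor), compound 1 `CC(C)c1cc2c(cc1O)[C@]13CCC[C@](C)(CO[C@@H]1O)[C@@H]3CC2` gives > 10000 nM as a limit of the assay, not a number. Compound 2 `CO[C@@H]1OC[C@@]2(C)CCC[C@@]13c1cc(O)c(C(C)C)cc1CC[C@@H]23` gives > 10000 nM as a limit too, so it holds no numeric place in the series. The picture so far is the limit of > 10000 nM in this assay, at which 2 of the 2 values shown sit, and nothing more.

Compound 3 `CO[C@H]1OC[C@@]2(C)CCC[C@@]13c1cc(O)c(C(C)C)cc1CC[C@@H]23` differs from compound 2 as follows: the two compounds have the same atoms and bonds and differ only in configuration as drawn: 1 of 4 stereo elements differ; a stereocentre at a saturated ring carbon is drawn R in compound 2 and S in compound 3 and, in words, a stereocentre at a saturated ring carbon is drawn R in compound 2 and S in compound 3. Going by the values given here, no measured pair shows what such an inversion does in this assay and no direction can be argued from the data. The expectation is therefore no step beyond the scatter, with compound 2 and its limit of > 10000 nM as the only anchor. The estimated step that the limit leaves unreadable from compound 2 to compound 3 is expected to stay within the scatter. A report as a limit is again the expected outcome for compound 3. For compound 3 the estimate is 12000 nM within an expected range of 5000 nM to 30000 nM in this read-out.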

Compound 3, half-maximal inhibitory concentration: > 10000 nM
Compound 3 was reported as a limit; the forecaster's own chance of this, stated with the estimate: 80%; the middle value does not contradict the limit.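

In this assay compound 3 gives > 10000 nM, a limit of the assay and not a number. Going by these compounds alone, as compound 1 and compound 2 are also reported as limits, no step to compound 3 can be read. As far as these compounds go, whether the inverted stereocentre, or methyl in place of hydrogen on an oxygen on a saturated carbon, has any effect in this assay stays open.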